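The compounds below may be only part of what the source reports. "The series", "measured", "known", "first", "only" and "open" are said of these compounds alone.

Working notes on the series.

Compound 1 `CC(C)n1nc(Cc2cccc(Cl)c2Cl)c2c(N)ncnc21` is the parent of the pair measured in an ADME assay on microsomes from liver (Rattus norvegicus) for metabolic stability, read by LC-MS, using NADPH, with a stated time of 60 min; on this read-out higher numbers stand for fast clearance and lower numbers for slow clearance; in this assay compound 1 gives 0.19 mL/min. Compound 2 `CC(C)n1nc(C(O)c2cccc(Cl)c2Cl)c2c(N)ncnc21` carries a hydroxy on the saturated chain carbon bound to two aromatic carbons, and in this assay compound 2 gives 0.068 mL/min. Among the compounds with values here, the one measured step is a 2.8-fold lower number from compound 1 to compound 2 (0.45 log units; beyond the scatter). Within the data shown here, compound 2 therefore stands at the lower of the two numbers so far, with compound 1 as its only neighbour.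

Compound 3 `CC(C)n1nc(C(F)c2cccc(Cl)c2Cl)c2c(N)ncnc21` is the next point. It differs from compound 2 as follows: fluoro in place of hydroxy on a saturated chain carbon bound to two aromatic carbons. Among the measured compounds shown here, no measured step in this set carries a fluoro at that carbon, so only the step of a 2.8-fold lower number from compound 1 to compound 2 (0.45 log units; beyond the scatter) bears on the question, and it bears on it in reverse: the hydroxy leaves again, and what enters has not been sampled. Removing the hydroxy alone would point back toward compound 1; the fluoro is an unknown. The expectation for compound 3 is accordingly placed between the two measured numbers, closer to compound 2, as a step of a 1.8-fold higher number from compound 2 to compound 3 (0.25 log units; within the scatter). For compound 3 the estimate in this assay is 0.12 mL/min, with a range from 0.06 mL/min to 0.25 mL/min.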

Compound 3, intrinsic clearance in a liver preparation (reported as CLH), per the amount of preparation that the assay uses: 0.107 mL/min
Estimate against measurement, compound 3: 1.1-fold (0.05 log units) above; the measured number falls inside the stated range.
By their numbers in this assay, from the lowest: compounds 2, 3 and 1 (each within the scatter of the next, the first and the last beyond it).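

In this assay the fluoro on a saturated chain carbon bound to two aromatic carbons cannot be told apart from the hydroxy (a 1.6-fold higher number from compound 2 to compound 3 (0.20 log units; within the scatter)), although this change exchanges one heavy atom for one heavy atom and leaves that carbon with no hydrogen-bond donor or acceptor in the group. Nor can the fluoro be told apart from the hydrogen at that carbon (a 1.8-fold lower number from compound 1 to compound 3 (0.25 log units; within the scatter)), so compound 3 lies within the scatter of both neighbours, and only the hydroxy against the hydrogen remains a separated pair (a 2.8-fold lower number from compound 1 to compound 2 (0.45 log units; beyond the scatter)). No supporting measurement is available to account for any of these steps.

Open, going by these compounds, is whether a methoxy or an amine on the same carbon would read with compound 2 or with compound 1, and whether any group there gives a step beyond the scatter from compound 3. Also open, on these data alone, is whether the two mirror-image forms at that carbon read alike in compound 2 and compound 3.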